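Working notes: from compound 1 to compound 3

This account rests on a few compounds, and the source may have more. Where it says the series, first, only, none or still open, it means among the compounds named here.

Measured so far:
compound 1, `CC(C(=O)N1CCN(c2ccccc2)CC1)N1C(=O)CCC1=O`: 0%
compound 2, `CCC(C(=O)N1CCN(c2ccc(F)cc2)CC1)N1C(=O)CCC1=O`: 0%

In a functional assay on the whole organism (strain Swiss) with Mus musculus as the target, in the maximal electroshock model, with a stated time of 2 h, at a dose of 300 mg/kg by the intraperitoneal route (a higher number here means a stronger effect of the compound at the dose given, a lower number a weaker effect), compound 1 gives 0%. Compound 2, in this assay, gives 0%, which is level with compound 1 at the digits shown; the two values lie within the usual scatter of each other, so nothing here separates them. For the measured compounds named here, no pair of measured compounds differs in only one place, so no single structural step has yet been read against a number.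

Compound 3, `CC(C(=O)N1CCN(c2cccc(Cl)c2)CC1)N1C(=O)CCC1=O`, is the next compound for this assay. Against compound 1 it differs in one place: chloro in place of hydrogen on an aromatic carbon.

Both measured compounds sit at the floor of the read-out, and nothing in the series ties a change on this ring to a shift in this assay. For compound 3 the expected step from compound 1 is no change at the digits printed from compound 1 to compound 3 (within the scatter), that is none beyond the scatter. Compound 3 is therefore estimated at 0%, with a range from 0% to 20%.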

Compound 3, a percentage reported as activity, at one dose (the size of the read-out at that dose, not a potency): 50%
For compound 3 the middle estimate is 50 percentage points below the measured one, and the stated range ends below it.
By their numbers in this assay, from the lowest: compounds 1 and 2 (each within the scatter of the next); then compound 3.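

Chloro in place of hydrogen on an aromatic carbon, meta to a large group, gives a number 50 percentage points higher from compound 1 to compound 3 (beyond the scatter) in this assay. For the compounds shown here, this is the first single-place step that can be read, and it shows that the read-out can rise from the floor through a change on this ring alone, with the rest of the core of compound 1 unchanged. Nothing available accounts for the size of this step.

Going by these compounds, whether the step is specific to chloro stays open, as trifluoromethyl, methyl or methoxy at the same place could give a different read-out. Also open, on these data alone, are chloro on another carbon of the ring and, as this read-out comes from one dose, how compound 3 would behave across a range of doses.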